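Swapping the Furan for a Pyrrole on the Shared Core

The source may hold more compounds than are shown below. What is called first, only, known or untested is meant among the compounds shown, and "the series" means these compounds.

Compound 1 `OC[C@H]1O[C@@H](n2cc(F)c3c(-c4ccco4)ncnc32)[C@H](O)[C@@H]1O`: in a functional assay on HCT-116 cells (Homo sapiens), read by sulforhodamine B assay, with a stated time of 5 days (a higher number here means a weaker inhibitor of growth, a lower number a stronger inhibitor of growth), compound 1 gives 39 nM.
Compound 2 `OC[C@H]1O[C@@H](n2cc(F)c3c(-c4ccc[nH]4)ncnc32)[C@H](O)[C@@H]1O`: in this assay compound 2 gives 450 nM.

Compound 1 has the lowest of the two numbers; its nearest neighbour is compound 2, reached by a 12-fold higher number from compound 1 to compound 2 (1.06 log units; beyond the scatter). Compound 3 `OC[C@H]1O[C@@H](n2cc(F)c3c(-c4cc[nH]c4)ncnc32)[C@H](O)[C@@H]1O` differs from compound 1 in one place: 1H-pyrrol-3-yl in place of furan-2-yl on an aromatic carbon. Within the data shown here, the only measured step that bears on this change is a 12-fold higher number from compound 1 to compound 2 (1.06 log units; beyond the scatter), which was large. A weakening of similar size is therefore expected in this assay, namely a 9.0-fold higher number from compound 1 to compound 3 (0.95 log units; beyond the scatter). Compound 3 is thus estimated at 350 nM, with a range from 100 nM to 1200 nM.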

Compound 3, concentration for 50% growth inhibition: 250 nM
For compound 3 the middle estimate is 1.4-fold (0.15 log units) above the measured one, within the range that was stated.
By their numbers in this assay, from the lowest: compound 1; then compounds 3 and 2 (each within the scatter of the next).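

In this assay the step of a 6.4-fold higher number from compound 1 to compound 3 (0.81 log units; beyond the scatter) shows that the weaker result at this aromatic carbon holds for 1H-pyrrol-3-yl as well as for 1H-pyrrol-2-yl. The two pyrroles cannot be told apart, since the step of a 1.8-fold lower number from compound 2 to compound 3 (0.26 log units; within the scatter) gives no order between them. No measured evidence accompanies these results to explain them.

From the compounds shown here alone, whether furan-2-yl is special among such rings remains open. Furan-3-yl, thiophene-2-yl or a phenyl ring at this place could show how far the lower number of compound 1 extends.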